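The compounds below may be only part of what the source reports. "The series", "measured", "known", "first", "only" and "open" are said of these compounds alone.

Measured in a functional assay on DU-145 cells (Homo sapiens) for inhibition, read by trypan blue exclusion, with a stated time of 96 h; on this read-out higher numbers stand for weaker inhibition of growth and lower numbers for stronger inhibition of growth:
- Compound 1 `Cc1ccc(CS/C(=C/c2ccc(O)cc2)C(=O)c2ccc(Cl)cc2)cc1`: 10000 nM
- Compound 2 `O=C(/C(=C\c1ccc(F)cc1C(F)(F)F)SCc1ccc(F)cc1)c1ccc(Br)cc1`: 10000 nM
- Compound 3 `O=C(/C(=C\c1ccc(Br)cc1)S(=O)(=O)c1ccc(Br)cc1)c1ccc(Br)cc1`: 10000 nM

Compound 1 stands level with compound 2 and compound 3, and the three show no difference in this assay. Within the data shown here, no step between measured compounds is available to show what a single structural change can do here.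

Compound 4 `Cc1ccc(CS/C(=C/c2ccc(O)c(O)c2O)C(=O)c2ccc(Cl)cc2)cc1` keeps the core of compound 1 and differs in one place: 2,3,4-trihydroxyphenyl in place of 4-hydroxyphenyl on a double-bonded chain carbon bound to a double-bonded chain carbon. It carries 2,3,4-trihydroxyphenyl in place of 4-hydroxyphenyl on a double-bonded chain carbon bound to a double-bonded chain carbon. Among the measured compounds shown here, none of the measured compounds carries this group, so the data offer no direct precedent.

The expectation therefore starts from compound 1 at 10000 nM and leans only moderately towards stronger inhibition of growth in this assay, though a result within the scatter remains quite possible. The expected change is a 3.3-fold lower number from compound 1 to compound 4 (0.52 log units; beyond the scatter). For compound 4 the estimated value is 3000 nM, with an expected range from 500 nM to 10000 nM.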

Compound 4, concentration for 50% growth inhibition: 50000 nM
Beside the measured number, compound 4's estimate is 17-fold (1.22 log units) below it; the whole stated range lies below it.
By their numbers in this assay, from the lowest: compounds 1, 2 and 3 (each within the scatter of the next); then compound 4.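

In this assay, among these compounds, 2,3,4-trihydroxyphenyl in place of 4-hydroxyphenyl on a double-bonded chain carbon bound to a double-bonded chain carbon gives a 5.0-fold higher number from compound 1 to compound 4 (0.70 log units; beyond the scatter), the only single-place step in the set. Compounds 1, 2 and 3 stood level and could not show that a change here alters the read-out, whereas this step shows that it can, and that adding hydroxyl groups to this ring moves the result towards weaker inhibition of growth. Nothing measured here explains the step.

The compounds shown do not settle whether the step needs all the added hydroxyl groups, which a 3,4-dihydroxyphenyl or 4-methoxyphenyl group in this place might help to separate. They also leave open whether any group here, such as a 4-aminophenyl, could give a lower number than compound 1.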